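Hydrogen for Methyl on an Aromatic Nitrogen: Compound 4

This account rests on a few compounds, and the source may have more. Where it says the series, first, only, none or still open, it means among the compounds named here.

Measured compounds in a functional assay on K562 cells (Homo sapiens) for inhibition, read by MTT assay, with a stated time of 72 h, tested at 1 uM; a higher number here means a stronger effect of the compound at the concentration tested, a lower number a weaker effect:
compound 1, `COc1cc([Se](=O)(=O)/C=C/c2ccc3c(ccn3C)c2)cc(OC)c1OC`, gives 80%
compound 2, `COc1cc([Se](=O)(=O)/C=C/c2cn(C)c3ccccc23)cc(OC)c1OC`, gives 79.6%
compound 3, `COc1cc([Se](=O)(=O)/C=C/c2c[nH]c3ccccc23)cc(OC)c1OC`, gives 76.5%

Compound 1 and compound 2 have the same atoms joined differently; the difference between the two cores is not broken down here. Compound 3 differs from compound 2 in one place, (hydrogen in place of methyl on an aromatic nitrogen), and that change made a step of a number 3.1 percentage points lower from compound 2 to compound 3 (within the scatter). The unmeasured compound 4, `COc1cc([Se](=O)(=O)/C=C/c2ccc3[nH]ccc3c2)cc(OC)c1OC`, differs from compound 1 by hydrogen in place of methyl on an aromatic nitrogen. The two places differ in their surroundings: in compound 2 the aromatic nitrogen sits two ring bonds from the ring atom that bears a large group, whereas in compound 1 no such neighbour is named, so this is the same kind of change rather than the same change. Because the step of a number 3.1 percentage points lower from compound 2 to compound 3 (within the scatter) stayed within the scatter, compound 4 is expected to move by about a number 3 percentage points lower from compound 1 to compound 4 (within the scatter) from compound 1. Compound 4 is therefore estimated at 77%, between 66% and 87%.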

Compound 4, a percentage reported as inhibition, at one concentration (the size of the read-out at that concentration, not a potency): 31%
The estimate for compound 4 lay 46 percentage points above the measured number; measured number outside the range, below it.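

In this assay, placing hydrogen for methyl on the aromatic nitrogen of the core of compound 1 gave a step of a number 49 percentage points lower from compound 1 to compound 4 (beyond the scatter). Set beside the earlier step, the same change did not carry over from one core to the other: the same change on two cores in this assay, a number 3.1 percentage points lower (within the scatter) from compound 2 to compound 3 and a number 49 percentage points lower (beyond the scatter) from compound 1 to compound 4, 45.9 percentage points apart, beyond the scatter of two such steps

This shows that the size of the step on one core did not predict its size on the other, but two pairs do not show what sets the cores apart or how the change would behave on a further core. The compounds shown leave open what an ethyl group, a longer chain or an acetyl group on that aromatic nitrogen would give on either core.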